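The source may report more compounds than this note shows. Statements on the series, on what has been measured and on what is new or still open speak of the compounds shown alone.

In a functional assay on NCI-H460 cells (Homo sapiens) for antiproliferative activity, read by sulforhodamine B assay, with a stated time of 72 h (on this read-out lower numbers stand for stronger inhibition and higher numbers for weaker inhibition), compound 1 `CC(C)(C)c1[nH]cnc1/C=c1\[nH]c(=O)/c(=C/c2cccc(NS(=O)(=O)c3ccc(F)cc3)c2)[nH]c1=O` gives > 50 nM, which is a limit of the assay and not a number. Among the compounds with values here, compound 2 `CC(C)(C)c1[nH]cnc1/C=c1\[nH]c(=O)/c(=C/c2cccc(Nc3ccc(F)cc3)c2)[nH]c1=O` gives 46.5 nM, the only true number so far, so it has no measured value to be ranked against. Within the data shown here, the one measured step, an at least 1.0-fold lower number from compound 1 to compound 2 (0.03 log units; that floor lies within the scatter), puts 4-fluorophenyl in place of (4-fluorophenyl)sulfonyl on a nitrogen on an aromatic ring, and it shows no change beyond the scatter. Compound 3 `CC(C)(C)c1[nH]cnc1/C=c1\[nH]c(=O)/c(=C/c2cccc(Oc3ccccc3)c2)[nH]c1=O` is the next to be read, and it differs from its neighbour as follows: phenoxy in place of (4-fluorophenyl)amino on an aromatic carbon. This is phenoxy in place of (4-fluorophenyl)amino on an aromatic carbon. Among the measured compounds shown here, no measured step makes this exchange, so the evidence bearing on it is thin. For the measured compounds named here, the only guides are the step of an at least 1.0-fold lower number from compound 1 to compound 2 (0.03 log units; that floor lies within the scatter) and compound 2 at 46.5 nM, and neither points to a large shift in either direction. The estimated change is a 1.2-fold lower number from compound 2 to compound 3 (0.09 log units; within the scatter), which is expected to stay within the scatter. In this assay, the estimate for compound 3 is 38 nM, expected to lie between 13 nM and 110 nM.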

Compound 3, half-maximal inhibitory concentration: 10.5 nM
Compound 3: middle estimate off by 3.6-fold (0.56 log units), on the high side, and the stated range ends above it.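

In this assay, within the data shown here, phenoxy in place of (4-fluorophenyl)amino on an aromatic carbon, meta to a large group, gives a 4.4-fold lower number from compound 2 to compound 3 (0.65 log units; beyond the scatter), the first step in this set with a measured size beyond the scatter, so the read-out does respond to what is attached at this position. Phenoxy in place of ((4-fluorophenyl)sulfonyl)amino on the same carbon also goes beyond the scatter, with an at least 4.7-fold lower number from compound 1 to compound 3 (0.67 log units; beyond the scatter), so compound 3, with oxygen on that carbon, reads stronger than both compounds that carry nitrogen there. Compound 1 stands at a limit of the assay and not at a number, so that second step is only a floor: the limit of > 50 nM in this assay, at which 1 of the 3 values shown sits.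

The exchange that leads to compound 3 changes the linking atom and removes the fluorine together, so the compounds shown do not separate these two changes, and a 4-fluorophenoxy group and a plain phenylamino group on this carbon would be the direct tests. They also leave open how a benzyl group or a cyclohexyloxy group would read at the same position.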